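The source may hold more compounds than are shown below. What is called first, only, known or untested is meant among the compounds shown, and "the series" means these compounds.

Measured compounds:
compound 1 `Fc1ccc(-c2nc(-c3ccc4c(c3)nnn4C3CCCC3)no2)cc1`: 398 nM
compound 2 `Fc1ccc(-c2noc(C3CCc4c(nnn4C4CCCC4)C3)n2)cc1`: 398 nM; 31.6 nM (2 entries)
compound 3 `Fc1ccc(-c2noc(C3CCc4c(nnn4-c4ccc(F)cc4)C3)n2)cc1`: 15.9 nM

In a functional assay on U2OS cells for positive allosteric modulation of metabotropic glutamate receptor 5 (Homo sapiens), read by calcium flux, in the presence of a further agent that is not named here (on this read-out lower numbers stand for an effect already at smaller amounts and higher numbers for an effect only at larger amounts of compound), compound 3 gives the lowest of the two single numbers; the nearest is compound 1, whose value stands well above it, beyond the scatter. Compound 2 has no single number, only the spread shown in the several entries of compound 2 in this assay, 398 nM; 31.6 nM (2 entries), which itself stretches beyond the usual scatter of repeats.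

Compound 4 `Fc1ccc(-c2noc(C3CCc4c(nnn4-c4ccc(F)nc4)C3)n2)cc1` differs from compound 3 in one place: 6-fluoropyridin-3-yl in place of 4-fluorophenyl on an aromatic nitrogen. For the measured compounds named here, no measured pair shows this exchange. The expected step from compound 3 to compound 4, a 2.0-fold higher number from compound 3 to compound 4 (0.30 log units; within the scatter), is small, if anything upward, and within the scatter. Compound 4 is therefore estimated at 32 nM, with a range from 8 nM to 130 nM.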

Compound 4, half-maximal effective concentration: > 25100 nM
Compound 4: a limit, no number (the forecaster's own chance of this, stated with the estimate: 5%); at least 780-fold (2.89 log units) between middle value and limit.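

In this assay, 6-fluoropyridin-3-yl in place of 4-fluorophenyl on the aromatic nitrogen gives an at least 1500-fold higher number from compound 3 to compound 4 (3.19 log units; beyond the scatter). Compound 4 reads > 25100 nM, which is a limit of the assay and not a number. For the compounds shown here, this is the first single-place exchange, and it shows that one ring nitrogen in the aromatic group at this position is enough to produce a large step.

From the compounds shown here alone, how far compound 4 lies past its limit remains open. Also open, going by these compounds, is whether pyridin-3-yl without fluorine, pyridin-2-yl or a 4-aminophenyl group at this position would give a similar step.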